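This account rests on a few compounds, and the source may have more. Where it says the series, first, only, none or still open, it means among the compounds named here.

Compound 1 `CC(C)Nc1nc(NCc2ccco2)c2ccc(Cl)cc2n1`: <= 20000 nM
Compound 2 `CC(C)Nc1nc(NCc2ccco2)c2cc(Cl)ccc2n1`: <= 20000 nM
Compound 3 `Cc1ccc2c(NCc3ccco3)nc(NC(C)C)nc2c1`: <= 20000 nM

The read-out for these compounds is a physicochemical assay for solubility, at pH 7.4; a lower number here means a less soluble compound, a higher number a more soluble compound. For compound 1 the value <= 20000 nM is a limit of the assay, not a number. For compound 2 the value <= 20000 nM is likewise a limit. For compound 3 the value <= 20000 nM is a limit as well. What the three share is the limit of <= 20000 nM in this assay, at which 3 of the 3 values shown sit.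

Compound 1 and compound 3 differ in one place, (methyl in place of chloro on an aromatic carbon), and the step that the two limits leave unreadable from compound 1 to compound 3 stays unreadable, since both ends are limits. Compound 2 is built from the same atoms as compound 1, joined differently; the difference between the two cores is not broken down here.

Compound 4 `Cc1ccc2nc(NC(C)C)nc(NCc3ccco3)c2c1` has not yet been measured in this assay. It arises from compound 2 by the same change, (methyl in place of chloro on an aromatic carbon), at the same place as before. Because of the limit of <= 20000 nM in this assay, at which 3 of the 3 values shown sit, the step from compound 2 to compound 4 is expected to be small, a step that the limit leaves unreadable from compound 2 to compound 4. Compound 4 is expected to give 15000 nM, probably once more as a limit, between 3000 nM and 20000 nM.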

Compound 4, solubility: <= 20000 nM
Compound 4 was reported as a limit; the forecaster's own chance of this, stated with the estimate: 85%; the middle value does not contradict the limit.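

In this assay the step from chloro to methyl between compound 2 and compound 4 cannot be read, because both ends are limits and not numbers: the limit of <= 20000 nM in this assay, at which 4 of the 4 values shown sit.

The compounds shown leave open what actual solubility number each compound would give, and whether swapping chloro for methyl changes it at either place on the ring.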